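Replacing the Thiazole on the Pyrazoline Nitrogen with a Thioamide

This account rests on a few compounds, and the source may have more. Where it says the series, first, only, none or still open, it means among the compounds named here.

This account concerns three measured compounds and one that has not yet been tested in a physicochemical assay for inhibition, read by colorimetric assay, tested at 1 mg/mL; on this read-out lower numbers stand for less inhibition and higher numbers for more inhibition at the one concentration tested (going by the name of the read-out). Compound 1, `N#Cc1c(N)nc2c(c1-c1ccc(O)cc1)CCC/C2=C\c1ccc(O)cc1`, gives 8.69% in this assay. Compound 2, `CCN1C/C(=C\c2ccc(OC)cc2)C2=NN(c3nc(-c4ccc(Cl)cc4)cs3)C(c3ccc(OC)cc3)C2C1`, gives 82.6%. Compound 3, `COc1ccc(/C=C/C2=NN(c3nc(-c4ccccc4)cs3)C(c3ccc(OC)cc3)C2)cc1`, gives 76%.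

Among the three numbers, compound 3 stands second highest. Its nearest neighbour is compound 2, whose value is higher by an amount within the usual scatter of repeated measurements, so no order between the two can be claimed. Its furthest neighbour is compound 1, whose value is lower by an amount well beyond the scatter.

Compound 4 is `COc1ccc(/C=C/C2=NN(C(N)=S)C(c3ccc(OC)cc3)C2)cc1`. It differs from compound 3 in one place:

a group of 3 heavy atoms (1 carbon, 1 nitrogen, 1 sulfur; no ring) in place of a group of 11 heavy atoms (9 carbon, 1 nitrogen, 1 sulfur; one five-membered aromatic ring with 2 hetero atoms, one six-membered aromatic ring of carbon only), on an amine nitrogen in a ring

Among the compounds with values here, no step between two measured compounds isolates this particular change, so its effect is not known from the numbers at hand. Within the data shown here, both compounds that carry the 4-phenyl-1,3-thiazol-2-yl group on the ring nitrogen, compound 2 and compound 3, sit high in this assay, while the only compound without it, compound 1, is built on a different core and sits very low. The account therefore expects a moderate decrease for compound 4, a step of a number 16 percentage points lower from compound 3 to compound 4 (beyond the scatter), which lies just beyond the scatter. In this assay compound 4 is expected to give about 60%, with a plausible range from 35% to 85%.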

Compound 4, a percentage reported as inhibition, at one concentration (the size of the read-out at that concentration, not a potency): 84.5%
Compound 4: the middle estimate sits 24.5 percentage points below what was measured; low and high end bracket the measured number.
By their numbers in this assay, from the lowest: compound 1; then compounds 3, 2 and 4 (each within the scatter of the next).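

In this assay, exchanging the 4-phenyl-1,3-thiazol-2-yl group on the amine nitrogen in the ring for the thioamide gives a number 8.5 percentage points higher from compound 3 to compound 4 (within the scatter), so this read-out does not tell the two compounds apart. The earlier compounds shown here could not show this, since no measured pair isolated a change at this position: on this shared core, the read-out stays within the scatter when both aromatic rings of the departing group are gone and a small group with no ring stands in their place. No measurement at hand bears on why the two compounds read alike.

The compounds shown leave open whether the sulfur of the thioamide matters at this position, and whether a urea-type carboxamide with oxygen in its place, an acetyl group or a plain hydrogen on the same nitrogen would stay in this range. They also leave open how compound 3 and compound 4 would compare at other concentrations, as this read-out comes from a single concentration and gives no potency.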